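Shortening the Side Chain: Isobutyl Becomes Methyl

This account rests on a few compounds, and the source may have more. Where it says the series, first, only, none or still open, it means among the compounds named here.

Of the compounds shown here, three built on one shared core have so far been measured in a functional assay on A549 cells (Homo sapiens) for cytotoxicity, read by MTT assay; on this read-out lower numbers stand for stronger inhibition and higher numbers for weaker inhibition. Compound 1 `CC(C)C[C@@H](NC(=S)Nc1ccccc1)c1nc2ccccc2[nH]1` gives 18700 nM in this assay. Compound 2 `CC(C)C[C@H](NC(=S)Nc1ccccc1)c1nc2ccccc2[nH]1` gives 28600 nM, and the step of a 1.5-fold higher number from compound 1 to compound 2 (0.18 log units; within the scatter) stays within the scatter, which is unsurprising given (the fact that compounds 1 and 2 differ only in the configuration as drawn). Compound 3 `CC(C)C[C@H](NC(=S)Nc1cc(C(F)(F)F)cc(C(F)(F)F)c1)c1nc2ccccc2[nH]1`, carrying two trifluoromethyl groups, gives 17400 nM. Compound 1 therefore stands second highest of the three numbers, with compound 3 and compound 2 both within the scatter of it.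

Compound 4 `C[C@@H](NC(=S)Nc1ccccc1)c1nc2ccccc2[nH]1` has not yet been measured. It differs from compound 1 by hydrogen in place of isopropyl on a saturated chain carbon, two bonds along the chain from an amide-type nitrogen and an aromatic carbon, so the isobutyl chain of compound 1 becomes a methyl. Among the compounds with values here, no measured step touches this chain; the only measured step, from compound 1 to compound 2, concerns configuration alone and was within the scatter, so it offers no guide to a change in chain length. With nothing in the data pointing either way, a step no larger than the scatter is expected in this assay, the estimated step being a 1.3-fold higher number from compound 1 to compound 4 (0.13 log units; within the scatter). For compound 4 the expected value is 25000 nM, with a range from 9000 nM to 70000 nM.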

Compound 4, half-maximal inhibitory concentration: 14800 nM
Compound 4: the middle estimate sits 1.7-fold (0.23 log units) above what was measured, within the range that was stated.
By their numbers in this assay, from the lowest: compounds 4, 3, 1 and 2 (each within the scatter of the next).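

Replacing the isobutyl chain with methyl on this saturated chain carbon gives a 1.3-fold lower number from compound 1 to compound 4 (0.10 log units; within the scatter) in this assay, a step that stays within the scatter. Within the data shown here, this is the first measured change to the size of the chain at this carbon, since the earlier step here concerned configuration alone, and it shows that, on this pair, the isopropyl part of the chain can go without a step beyond the scatter. Nothing available explains why the chain change leaves the number within the scatter.

From the compounds shown here alone, whether the same holds for a longer chain, a benzyl group, or a chain ending in an amine or a carboxylic acid at this carbon remains open. Also open, going by these compounds, is how the methyl chain would behave alongside the two trifluoromethyl groups of compound 3.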